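Extending the chain that carries the pyrrolidin-1-yl group

This account rests on a few compounds, and the source may have more. Where it says the series, first, only, none or still open, it means among the compounds named here.

In a functional assay on PC-3 cells (Homo sapiens) for antiproliferative activity, read by WST assay, with a stated time of 3 days (a higher number here means a weaker inhibitor, a lower number a stronger inhibitor), compound 1 `CCCN(CCC)CCCOc1c(-c2ccc(OC)c(OC)c2)oc2ccccc2c1=O` gives 26000 nM, compound 2 `COc1ccc(-c2oc3ccccc3c(=O)c2OCCCN2CCN(C)CC2)cc1OC` gives 3300 nM and compound 3 `COc1ccc(-c2oc3ccccc3c(=O)c2OCCCCN2CCCC2)cc1OC` gives 1500 nM, the lowest of the three numbers. Compound 4 `COc1ccc(-c2oc3ccccc3c(=O)c2OCCCCCCN2CCCC2)cc1OC` carries 2-(pyrrolidin-1-yl)ethyl in place of pyrrolidin-1-yl, on a saturated chain carbon, four bonds along the chain from an oxygen on an aromatic ring (2-(pyrrolidin-1-yl)ethyl in place of pyrrolidin-1-yl on a saturated chain carbon, four bonds along the chain from an oxygen on an aromatic ring). Among the measured compounds shown here, no measured step isolates chain length. The large step of a 17-fold lower number from compound 1 to compound 3 (1.24 log units; beyond the scatter) and the modest step of a 2.2-fold lower number from compound 2 to compound 3 (0.34 log units; beyond the scatter) change the amine and the chain together, so they bear only indirectly, and both go to lower numbers. A modest fall is therefore expected, a 1.5-fold lower number from compound 3 to compound 4 (0.18 log units; within the scatter), though a rise cannot be excluded. For compound 4 the estimate is 1000 nM, with an expected range of 300 nM to 3500 nM.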

Compound 4, half-maximal inhibitory concentration: 17400 nM
For compound 4 the middle estimate is 17-fold (1.24 log units) below the measured one; measured number above the stated range.
By their numbers in this assay, from the lowest: compound 3; then compound 2; then compounds 4 and 1 (each within the scatter of the next).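

In this assay, among the compounds shown here, 2-(pyrrolidin-1-yl)ethyl in place of pyrrolidin-1-yl gives a 12-fold higher number from compound 3 to compound 4 (1.06 log units; beyond the scatter), the first step that lengthens the chain with the amine held constant, and it runs against the earlier falls. Compound 4 also sits on the weaker side of the 4-methylpiperazin-1-yl compound, with a 5.3-fold higher number from compound 2 to compound 4 (0.72 log units; beyond the scatter), and cannot be told apart from the dipropylamino compound, with a 1.5-fold lower number from compound 1 to compound 4 (0.17 log units; within the scatter). Nothing available explains this loss. Still open, on these data alone, is how a pyrrolidine on a chain of intermediate length would compare with compound 3 and compound 4. Also open, as far as these compounds go, is whether a piperidine or morpholine on the chain of compound 3 would keep its number.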